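This account rests on a few compounds, and the source may have more. Where it says the series, first, only, none or still open, it means among the compounds named here.

Working notes on the series. Compound 1 `c1ccc(Sc2ncnc3[nH]cnc23)cc1` shows no measurable effect in an assay on isolated protein for inhibition of RAC-alpha serine/threonine-protein kinase (Homo sapiens), tested at 30 uM (on this read-out higher numbers stand for more inhibition at the one concentration tested (going by the name of the read-out) and lower numbers for less inhibition), where compound 1 gives 0%. Compound 2 `Fc1ccc(Sc2ncnc3[nH]cnc23)cc1` carries the change fluoro in place of hydrogen on an aromatic carbon relative to compound 1, and in this assay compound 2 gives 0%, so the step is no change at the digits printed from compound 1 to compound 2 (within the scatter). Compound 3 `c1ccc(C[n+]2c[nH]c3ncncc32)cc1` rests on a different core; how the two cores differ is not broken down here. In this assay compound 3 gives 9%, a number that sits within the scatter of the values of compound 1 and compound 2, so no order among the three can be read.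

Compound 4 `Fc1ccc(C[n+]2c[nH]c3ncncc32)cc1` is not yet measured. It differs from compound 3 by fluoro in place of hydrogen on an aromatic carbon, the same change as that from compound 1 to compound 2, with the place described in identical words. Among the measured compounds shown here, because no change at the digits printed from compound 1 to compound 2 (within the scatter) is the only measured instance of this change, the step from compound 3 to compound 4 is expected to be similarly small, estimated as no change at the digits printed from compound 3 to compound 4 (within the scatter). For compound 4 the expected value in this assay is therefore 9%, estimated to lie between 0% and 22%.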

Compound 4, a percentage reported as inhibition, at one concentration (the size of the read-out at that concentration, not a potency): 8%
For compound 4 the middle estimate is 1 percentage points above the measured one, and the stated range covers the measured number.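

Carried to the second core, fluoro in place of hydrogen on an aromatic carbon gives, in this assay, a number 1 percentage points lower from compound 3 to compound 4 (within the scatter). Set beside the earlier step, the change reads alike on the two cores: the same change on two cores in this assay, no change at the digits printed (within the scatter) from compound 1 to compound 2 and a number 1 percentage points lower (within the scatter) from compound 3 to compound 4, 1 percentage points apart, within the scatter of two such steps This shows that, para to a large group, the change leaves no visible step on either core, but with compound 1 at 0% and compound 3 at 9%, both starting points show little inhibition, and the absence of a step here says nothing about how the change would behave on a compound with a clear read-out.

The compounds shown leave open whether anything on the six-membered aromatic ring can move this read-out beyond the scatter, with fluoro the only group shown there. An amine or a carboxylic acid in that place, or a longer chain between the aromatic ring and the core, remains an open question for both cores.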